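From chlorothiazole to fluoropyridine on the sulfonyl sulfur

This account rests on a few compounds, and the source may have more. Where it says the series, first, only, none or still open, it means among the compounds named here.

Of the compounds shown here, three sharing one core have been tested in an ADME assay on HCT-116 cells (Homo sapiens) for cytotoxicity, read by CellTiter-Glo, with a stated time of 72 h (on this read-out lower numbers stand for stronger inhibition and higher numbers for weaker inhibition), and none has yet given a readable number. Compound 1 (`CC1CCN(C2CCN(S(=O)(=O)c3cccnc3Cl)CC2)CC1`) gives > 10000 nM, which is a limit of the assay. Compound 2 (`CC1CCN(C2CCN(S(=O)(=O)c3ccc(C#N)cc3)CC2)CC1`) gives > 5000 nM, also a limit. Compound 3 (`CC1CCN(C2CCN(S(=O)(=O)c3cnc(Cl)s3)CC2)CC1`) gives > 10000 nM, again a limit, so its true standing is not known.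

Compound 4 (`CC1CCN(C2CCN(S(=O)(=O)c3cccnc3F)CC2)CC1`) has not been measured. It carries 2-fluoropyridin-3-yl in place of 2-chloro-1,3-thiazol-5-yl on a sulfonyl sulfur.

Three measured steps change this same place: a step that the two limits leave unreadable from compound 1 to compound 2, a step that the two limits leave unreadable from compound 1 to compound 3 and a step that the two limits leave unreadable from compound 2 to compound 3. Limits stand at both ends of each one, so none of them has a size that can be read. Still, all three groups tried on the sulfonyl sulfur have ended in a limit, and they give no sign of a change in either direction. No step beyond the scatter is therefore expected in this assay, and the expected change is a number no higher from compound 3 to compound 4 (the limit leaves the size open). The assay will quite likely report another limit. For compound 4 the estimated value is 10000 nM, within an expected range from 5000 nM to 20000 nM.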

Compound 4, half-maximal inhibitory concentration: > 10000 nM
Compound 4: a limit, no number; the forecaster's own chance of this, stated with the estimate: 85%; the middle value lies on the limit itself.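

In this assay compound 4 gives > 10000 nM, which is a limit of the assay and not a number. Limits stand at both ends of the steps linking compound 4 to compound 1, compound 2 and compound 3, and none of these steps can be read. The compounds shown leave open where any of them truly stands, and whether changing the group on the sulfonyl sulfur alters the read-out at all.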